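One Acetyl Restored on a Diol Core

The source may report more compounds than this note shows. Statements on the series, on what has been measured and on what is new or still open speak of the compounds shown alone.

Two measured compounds share one core. Compound 1 `C=C1CC[C@@H]2[C@](C)(CO[Si](C)(C)C(C)(C)C)[C@H](OC(C)=O)CC[C@@]2(C)[C@@H]1C/C=C1/C(=O)OC[C@H]1OC(C)=O` carries acetyl groups on both of its free oxygens; compound 2 `C=C1CC[C@@H]2[C@](C)(CO[Si](C)(C)C(C)(C)C)[C@H](O)CC[C@@]2(C)[C@@H]1C/C=C1/C(=O)OC[C@H]1O` carries a hydrogen on each of those oxygens instead. In a functional assay on P388 cells (Mus musculus) for cytotoxicity, read by sulforhodamine B assay (a higher number here means that more compound is needed for the effect, a lower number that less compound is needed), compound 1 gives 0.34 uM, while compound 2 gives 8.39 uM. Of these two numbers, compound 2 has the higher one, so more of compound 2 is needed for the same effect, and the gap between them lies well beyond the usual scatter of repeated measurements.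

Compound 3 `C=C1CC[C@@H]2[C@](C)(CO[Si](C)(C)C(C)(C)C)[C@H](OC(C)=O)CC[C@@]2(C)[C@@H]1C/C=C1/C(=O)OC[C@H]1O` has not yet been measured. It differs from compound 2 in one place: acetyl in place of hydrogen on an oxygen on a saturated carbon. The other oxygen keeps its hydrogen, so compound 3 stands between compound 2 and compound 1 in its number of acetyl groups.

Among the compounds with values here, no measured step covers a single acetyl alone. Because compound 1 gives 0.34 uM with both acetyls and compound 2 gives 8.39 uM with neither, one acetyl is expected to recover part of that difference. The expected step is a 4.2-fold lower number from compound 2 to compound 3 (0.62 log units; beyond the scatter), a decrease larger than the scatter. Compound 3 is estimated at 2 uM in this assay, with a likely range from 0.5 uM to 6 uM.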

Compound 3, concentration for half-maximal effect: 1.71 uM
Compound 3: the middle estimate sits 1.2-fold (0.07 log units) above what was measured, within the range that was stated.
By their numbers in this assay, from the lowest: compound 1; then compound 3; then compound 2.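

Placing a single acetyl on the oxygen on a saturated carbon whose other neighbours are saturated ring carbons is enough to shift the result in this assay: the measured change is a 4.9-fold lower number from compound 2 to compound 3 (0.69 log units; beyond the scatter) and needs no help from the second oxygen. The other oxygen also matters when this first acetyl is already in place, since hydrogen in place of acetyl there gives a 5.0-fold higher number from compound 1 to compound 3 (0.70 log units; beyond the scatter) for the remaining change. Each of these single changes therefore lies beyond the scatter, so within these three compounds neither oxygen alone accounts for the whole difference in the series, and no measurement here bears on why the acetyl groups have this effect.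

The compounds shown leave open how a compound with acetyl only on the other oxygen would behave, and so whether the two positions are interchangeable. They also leave open whether the effect belongs to acetyl itself or would persist with a benzoyl group, a longer chain such as butanoyl, or a methyl ether on the same oxygen.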